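A trimethoxyphenyl swap on compound 1

The source may report more compounds than this note shows. Statements on the series, on what has been measured and on what is new or still open speak of the compounds shown alone.

Among the measured compounds shown here, in a functional assay on HeLa cells (Homo sapiens) for antiproliferative activity, read by sulforhodamine B assay, with a stated time of 48 h (a lower number here means a stronger inhibitor, a higher number a weaker inhibitor), compound 1 (`COc1cc(OC)c2sc(-c3ccc(N/C=C\C(=O)c4ccc(OC)c(O)c4)c(C)c3)nc2c1`) gives 16100 nM and compound 2 (`COc1cc(OC)c2sc(-c3ccc(N/C=C\C(=O)c4ccc(OC)c(O)c4)cc3)nc2c1`) gives 12100 nM as the only two numbers so far, and they lie within the scatter of each other. Compound 3 (`COc1cc(OC)c2sc(-c3ccc(N/C=C\C(=O)c4cc(OC)c(OC)c(OC)c4)c(C)c3)nc2c1`) keeps the core of compound 1 and carries 3,4,5-trimethoxyphenyl in place of 3-hydroxy-4-methoxyphenyl on a carbonyl carbon. For the measured compounds named here, the single measured step, a 1.3-fold lower number from compound 1 to compound 2 (0.12 log units; within the scatter) for hydrogen in place of methyl on an aromatic carbon, lies elsewhere in the molecule. Going by the values given here, no measured step touches the group that changes here, so it offers only weak guidance, and no step beyond the scatter is expected. The expected step is a 1.2-fold lower number from compound 1 to compound 3 (0.09 log units; within the scatter) on this estimate, with its direction uncertain. For compound 3 the estimated value is 13000 nM in this assay with 4000 nM to 40000 nM as the expected range.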

Compound 3, half-maximal inhibitory concentration: 16400 nM
Compound 3: middle estimate off by 1.3-fold (0.10 log units), on the low side; low and high end bracket the measured number.
By their numbers in this assay, from the lowest: compounds 2, 1 and 3 (each within the scatter of the next).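

In this assay, 3,4,5-trimethoxyphenyl in place of 3-hydroxy-4-methoxyphenyl on a carbonyl carbon gives a 1.0-fold higher number from compound 1 to compound 3 (0.01 log units; within the scatter) and so the two numbers cannot be told apart. Among the compounds shown here, this is the first measured change at this position, which the earlier pair of compounds left untouched. The hydrogen-bond donor of 3-hydroxy-4-methoxyphenyl is absent from 3,4,5-trimethoxyphenyl, and in this single pair that exchange comes with no step beyond the scatter, though nothing measured here offers an explanation for the result.

The compounds shown leave open whether a different group on this carbonyl carbon, such as an aminophenyl or a phenyl bearing a carboxylic acid, would give a step beyond the scatter. They also leave open whether 3,4,5-trimethoxyphenyl would behave the same way with hydrogen in place of methyl on the aromatic carbon.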